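The source may report more compounds than this note shows. Statements on the series, on what has been measured and on what is new or still open speak of the compounds shown alone.

Compound 1, `O=C1N[C@H]2[C@H](CS[C@H]2CCCCCc2cn(Cc3ccccc3O)nn2)N1`: in an assay on isolated protein for inhibition of biotin--protein ligase (Homo sapiens), read by scintillation counting, with a stated time of 10 min (a higher number here means a weaker inhibitor, a lower number a stronger inhibitor), compound 1 gives > 16000 nM, which is a limit of the assay and not a number.
Compound 2, `O=C1N[C@H]2[C@H](CS[C@H]2CCCCCc2cn(Cc3cccc(O)c3)nn2)N1`: in this assay compound 2 gives > 16000 nM, again a limit.
Compound 3, `O=C1N[C@H]2[C@H](CS[C@H]2CCCCCc2cn(Cc3ccc(I)cc3)nn2)N1`: in this assay compound 3 gives > 16000 nM, also a limit.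

All three measured values sit at the same limit, so compound 3 cannot be placed above or below the other two; the limit of > 16000 nM in this assay, at which 3 of the 3 values shown sit, records that every value shown rests there. The three steps among these measured compounds are therefore unreadable: a step that the two limits leave unreadable from compound 1 to compound 2, a step that the two limits leave unreadable from compound 1 to compound 3, a step that the two limits leave unreadable from compound 2 to compound 3.

Compound 4, `O=C1N[C@H]2[C@H](CS[C@H]2CCCCCc2cn(Cc3ccc(Cl)cc3)nn2)N1`, is not yet measured. It differs from compound 3 by chloro in place of iodo on an aromatic carbon. Among the measured compounds shown here, none of the measured steps touches that position, and none has a readable size, so no direction can be drawn from them. The expectation for compound 4 in this assay is therefore only that it stays near where compound 3 sits, an estimated step that the limit leaves unreadable from compound 3 to compound 4. Compound 4 is estimated at 20000 nM, with a range from 8000 nM to 60000 nM, most likely reported again as a limit.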

Compound 4, inhibition constant: > 16000 nM
Compound 4: a limit, no number; the forecaster's own chance of this, stated with the estimate: 80%; the middle value does not contradict the limit.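

Compound 4 gives > 16000 nM in this assay, a limit and not a number. Its steps to compound 1, compound 2 and compound 3 therefore cannot be read: the limit of > 16000 nM in this assay, at which 4 of the 4 values shown sit.

The compounds shown leave open how these four rank against one another and what change would give a readable inhibition constant.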